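Removing the Aromatic Methyl from an Enone Ester

This account rests on a few compounds, and the source may have more. Where it says the series, first, only, none or still open, it means among the compounds named here.

Measured so far:
compound 1, `CCCCC(=O)/C(C)=C(/C)C(=O)O`: 0.9
compound 2, `COC(=O)/C=C/C(=O)c1ccc(C)cc1`: 2.74

In a physicochemical assay for lipophilicity (a lower number here means a more polar compound, a higher number a more lipophilic compound), compound 2 stands highest of the two numbers. Its nearest neighbour is compound 1, whose number lies well below it, a gap far beyond the usual scatter of this measurement.

The compound to be measured next is compound 3, `COC(=O)/C=C/C(=O)c1ccccc1`. It differs from compound 2 in one place: hydrogen in place of methyl on an aromatic carbon. No other change is made, and the two compounds are otherwise the same.

Among the measured compounds shown here, since no step of this kind has yet been measured within the set, the expectation rests on compound 2 alone. A small downward step from compound 2 to compound 3 is expected, of a size somewhat beyond the scatter, namely a number 0.49 log units lower from compound 2 to compound 3 (beyond the scatter). Compound 3 is accordingly expected to give about 2.25, with a likely range from 1.9 to 2.6.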

Compound 3, partition coefficient: 2.24
For compound 3 the middle estimate is 0.01 log units above the measured one, within the range that was stated.
By their numbers in this assay, from the lowest: compound 1; then compound 3; then compound 2.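

Hydrogen in place of methyl on an aromatic carbon, para to a group of 8 heavy atoms, gives a number 0.50 log units lower from compound 2 to compound 3 (beyond the scatter) in this assay. Among the compounds shown here, this is the first step in the set that can be read at a single place, as the earlier compounds offered no pair differing in one place, and it shows that this one change on the ring is enough to move the number beyond the scatter. Nothing at hand gives a reason for the size of this step.

The compounds shown leave open whether a chlorine, a methoxy group or an amine at this place would raise or lower the number. They also leave open whether the same change gives a step of similar size on another core.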